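A few compounds are considered here, and "the series" means these few. Any claim that something is new, unique, unknown or untested is made for them only; others in the source may bear on it.

Compound 1 `COc1cc(-c2cc(/C=C/C(=O)c3ccc(N)cc3)[nH]n2)cc(OC)c1OC` and compound 2 `COc1ccc(C(=O)/C=C/c2cc(-c3cc(OC)c(OC)c(OC)c3)n[nH]2)cc1` share a core and differ only in one aromatic substituent. In a functional assay on SR cells (Homo sapiens) for inhibition, read by sulforhodamine B assay, with a stated time of 48 h (a lower number here means that less compound is tolerated, a higher number that more compound is tolerated), compound 1 reaches only the limit of the assay, given as > 100000 nM. In this assay compound 2 likewise stops at a limit, given as > 100000 nM. The step that the two limits leave unreadable from compound 1 to compound 2 therefore cannot be read, since the limit of > 100000 nM in this assay, at which 2 of the 2 values shown sit, holds for both values shown. Compound 2 thus stands at the limit of this assay, with no number of its own. Compound 3 `COc1cc(-c2cc(/C=C/C(=O)c3ccc(F)c(F)c3)[nH]n2)cc(OC)c1OC` is not yet measured; it differs from compound 2 by 3,4-difluorophenyl in place of 4-methoxyphenyl on a carbonyl carbon. Among the compounds with values here, no measured step bears on this change, so no direction beyond the scatter can be claimed. Compound 3 is therefore expected to sit near the same limit, an estimated 100000 nM with a range from 30000 nM to 300000 nM. The step of a number no higher from compound 2 to compound 3 (the limit leaves the size open) is expected to be small.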

Compound 3, concentration lethal to 50% of the cells: > 100000 nM
Compound 3 gave a limit, no number (the forecaster's own chance of this, stated with the estimate: 70%); the middle value lies on the limit itself.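

No step among compound 1, compound 2 and compound 3 can be read in this assay, since each stops at a limit and gives no number: the limit of > 100000 nM in this assay, at which 3 of the 3 values shown sit.

The compounds shown leave open whether any group on the carbonyl carbon would give a readable number in this assay.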